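This account rests on a few compounds, and the source may have more. Where it says the series, first, only, none or still open, it means among the compounds named here.

The series shares one core, shown in compound 1 `C=CCn1c(=O)/c(=C\c2ccc(F)c(Br)c2)[nH]c(=O)/c1=C\c1ccccc1OC`, compound 2 `C=CCn1c(=O)/c(=C\c2cccc(Br)c2)[nH]c(=O)/c1=C\c1cccc(Br)c1` and compound 3 `C=CCn1c(=O)/c(=C\c2ccccc2F)[nH]c(=O)/c1=C\c1ccccc1OC`, each carrying two arylidene arms. In a functional assay on BGC-823 cells (Homo sapiens) for cytotoxicity, read by CCK-8 assay, with a stated time of 72 h (a higher number here means a weaker inhibitor, a lower number a stronger inhibitor), compound 1 gives "not active" (no number reported), and compound 2 likewise gives "not active" (no number reported). Compound 3 is the only member for which a number is reported: in this assay compound 3 gives 18900 nM, so it stands alone among the numbers shown, with the other two entries recorded without a value. Compound 4 `C=CCn1c(=O)/c(=C\c2ccc(Cl)c(Cl)c2)[nH]c(=O)/c1=C\c1ccccc1OC` has not yet been tested. It differs from compound 3 in one place: 3,4-dichlorophenyl in place of 2-fluorophenyl on a double-bonded chain carbon bound to an aromatic carbon. Among the compounds with values here, since neither compound 1 nor compound 2 was reported with a number, there is no measured step between any two members to size this change against. What can be said is that compound 1, which carries a different halogenated ring on the same arm, was recorded as not active, and compound 3 itself is weak. On that basis compound 4 is expected to land near compound 3 or weaker, and the estimated step is a 1.3-fold higher number from compound 3 to compound 4 (0.12 log units; within the scatter). Compound 4 is estimated at 25000 nM in this assay. For compound 4 the expected range runs from 8000 nM to 80000 nM.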

Compound 4, half-maximal inhibitory concentration: "not active" (no number reported)
Nothing numeric was reported for compound 4; no gap can be computed for the estimate.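

Within the data shown here, compound 4 gives "not active" (no number reported) in this assay and so, with no number beside that of compound 3, no step between the two can be read. No measured evidence bears on this result. The compounds shown leave open how a change on either arylidene arm shifts the number, with compound 3 alone carrying one.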